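This account rests on a few compounds, and the source may have more. Where it says the series, first, only, none or still open, it means among the compounds named here.

Measured compounds:
compound 1 `COC(=O)c1nc(C)n(-c2ccc(OC)cc2)n1` gives > 100000 nM
compound 2 `COC(=O)c1nc(C(C)C)n(-c2ccc(F)cc2)n1` gives 6170 nM

Two compounds have been run in a functional assay on NCI-H226 cells (Homo sapiens) for inhibition, read by MTT assay, with a stated time of 72 h; on this read-out higher numbers stand for weaker inhibition of growth and lower numbers for stronger inhibition of growth. Compound 1 `COC(=O)c1nc(C)n(-c2ccc(OC)cc2)n1` reached only (the limit of > 100000 nM in this assay, at which 1 of the 2 values shown sits), which is a limit of the assay and not a number. Compound 2 `COC(=O)c1nc(C(C)C)n(-c2ccc(F)cc2)n1` gives 6170 nM, and this is the only number shown, so compound 2 stands alone as the sole point with a measured value. Going by the values given here, no pair of measured compounds differs in one place, so no measured step exists to compare with.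

Compound 3 `COC(=O)c1nc(-c2ccccc2)n(-c2ccc(F)cc2)n1` is the compound still to be measured. It differs from compound 2 by phenyl in place of isopropyl on an aromatic carbon. Among the compounds with values here, with no measured step covering a change of this kind, the expectation rests on compound 2 and its value 6170 nM alone, and the estimated step is a 1.5-fold lower number from compound 2 to compound 3 (0.19 log units; within the scatter), which is not expected to lie clearly beyond the scatter. Compound 3 is therefore estimated at 4000 nM, with a range from 1000 nM to 20000 nM.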

Compound 3, concentration for 50% growth inhibition: 89300 nM
Estimate against measurement, compound 3: 22-fold (1.35 log units) below; the measured number lies above the stated range.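

In this assay, going by these compounds alone, the exchange of isopropyl for phenyl on this aromatic carbon gives a 14-fold higher number from compound 2 to compound 3 (1.16 log units; beyond the scatter), the first step that can be read, and it stands for much weaker inhibition of growth. It shows that this carbon, between two ring nitrogen atoms, is not indifferent to the group it carries: with the rest of the structure unchanged, phenyl is clearly worse than isopropyl here, although this rests on a single pair. Nothing in the data shown gives a reason for this loss of inhibition.

One pair cannot separate the effect of the aromatic ring from that of the larger count of heavy atoms in phenyl, and a cyclohexyl or tert-butyl group on this carbon would speak to that question. Within the data shown here, compound 1 carries methyl at this carbon but also differs from compound 2 in a second place, so it gives no step, and how methyl, ethyl or a longer chain would compare with isopropyl on the otherwise unchanged structure stays open.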